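Moving the Chloro Group on the Imine-Bound Ring

The compounds below may be only part of what the source reports. "The series", "measured", "known", "first", "only" and "open" are said of these compounds alone.

Compound 1, `CC(=O)/C(=N\c1ccccc1)NNc1ccccc1C(F)(F)F`: 2260 nM
Compound 2, `CC(=O)/C(=N\c1ccccc1Cl)NNc1ccccc1C(F)(F)F`: > 10000 nM

In an assay on isolated protein for binding affinity to corticotropin-releasing factor receptor 1 (Homo sapiens) (on this read-out lower numbers stand for stronger inhibition and higher numbers for weaker inhibition), compound 1 gives 2260 nM. Compound 2 reaches only > 10000 nM, which is a limit of the measurement and not a number (the limit of > 10000 nM in this assay, at which 1 of the 2 values shown sits). The step of an at least 4.4-fold higher number from compound 1 to compound 2 (0.64 log units; beyond the scatter) therefore weakened binding. Compound 3, `CC(=O)/C(=N\c1ccc(Cl)cc1)NNc1ccccc1C(F)(F)F`, differs from compound 2 by 4-chlorophenyl in place of 2-chlorophenyl on a double-bonded nitrogen. Going by the values given here, no measured step moves a chloro group, so the step is expected to be an at least 2.0-fold lower number from compound 2 to compound 3 (0.30 log units; that floor lies within the scatter), a partial return toward compound 1. Compound 3 is estimated at 5000 nM, within 1200 nM to 20000 nM.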

Compound 3, inhibition constant: > 10000 nM
Compound 3 was reported as a limit; the forecaster's own chance of this, stated with the estimate: 35%; middle value at least 2.0-fold (0.30 log units) from the limit.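

With 4-chlorophenyl in place of the unsubstituted ring on the double-bonded nitrogen, binding is again weaker, with an at least 4.4-fold higher number from compound 1 to compound 3 (0.64 log units; beyond the scatter), so the loss is not confined to 2-chlorophenyl. Compound 3 gives > 10000 nM, which is a limit and not a number. The step between compound 2 and compound 3 cannot be read, so neither chloro placement can be ranked over the other in this assay: the limit of > 10000 nM in this assay, at which 2 of the 3 values shown sit.

Going by these compounds, whether a fluoro group, a methoxy group or an amine on this ring would keep binding stays open.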